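A few compounds are considered here, and "the series" means these few. Any claim that something is new, unique, unknown or untested is made for them only; others in the source may bear on it.

Measured so far:
- Compound 1 `Cc1ccc(C[C@H]2C(=O)OC[C@@H]2Cc2ccccc2)cc1`: "not determined" (no result reported)
- Compound 2 `COc1cc(C[C@H]2C(=O)OC[C@@H]2Cc2ccccc2)ccc1O`: "not determined" (no result reported)
- Compound 3 `O=C1OC[C@H](Cc2ccccc2)[C@H]1Cc1ccc(Cl)c(Cl)c1`: 26000 nM

The three compounds were taken into a functional assay on HeLa cells (Homo sapiens) for cytotoxicity, read by WST assay, with a stated time of 48 h (a lower number here means that less compound is needed, a higher number that more compound is needed for the effect), but only one of them yielded a number. There, compound 3 gives 26000 nM. Going by the values given here, compound 1 and compound 2 have no reported result, so compound 3 cannot be ranked against anything, and no step between measured compounds exists to show how this series responds to a structural change.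

The next compound is compound 4 `CCCCOc1ccccc1C[C@H]1COC(=O)[C@@H]1Cc1ccc(Cl)c(Cl)c1`, which keeps the core of compound 3 and carries one addition: butoxy in place of hydrogen on an aromatic carbon.

Among the compounds with values here, with no measured step available, any expectation is tentative, and the single anchor is compound 3 at 26000 nM. The expected change is a 2.4-fold lower number from compound 3 to compound 4 (0.37 log units; beyond the scatter), a modest estimated move toward the lower numbers of this assay, meaning that somewhat less compound would be needed, although a result close to that of compound 3 would not be surprising. The estimated value for compound 4 is 11000 nM. The expected range runs from 3500 nM to 35000 nM.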

Compound 4, half-maximal effective concentration: > 100000 nM
Compound 4: only a limit was reported; the forecaster's own chance of this, stated with the estimate: 12%; at least 9.0-fold (0.95 log units) between middle value and limit.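

In this assay the series now has its first readable step: butoxy in place of hydrogen on an aromatic carbon, ortho to a large group, gives an at least 3.8-fold higher number from compound 3 to compound 4 (0.58 log units; beyond the scatter). That step is open at its upper end, because compound 4 reached only a limit of the assay and not a number: the limit of > 100000 nM in this assay, at which 1 of the 4 values shown sits. Going by these compounds alone, the direction is nonetheless clear, which the earlier compounds, with only one number among them, could not show: at this place on the six-membered aromatic ring, the addition of butoxy to the core of compound 3 moves the read-out toward more compound being needed, not less.

Whether this rise belongs to the butoxy chain in particular or would follow any addition at this carbon stays open, since a smaller methoxy, a hydroxyl or an amine at the same place is not among the compounds shown. Also open, as far as these compounds go, is how far the number climbs beyond the limit, and whether butoxy on a different carbon of that ring would give the same direction of change.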